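Aryl exchange on the shared core and solubility

This account rests on a few compounds, and the source may have more. Where it says the series, first, only, none or still open, it means among the compounds named here.

The three measured compounds differ only in the aryl group on the shared core. In a physicochemical assay for solubility, using the shake flask method, in phosphate buffer, with a stated time of 24 h, at pH 7.2 (a lower number here means a less soluble compound, a higher number a more soluble compound), compound 1 `Cn1c(-c2cccs2)c(C2CCCCC2)c2ccc(C(=O)NC(C)(C)C(=O)Nc3ccc(/C=C/C(=O)O)cc3)cc21` reaches only a limit, < 0.1 ug/mL. Compound 2 `Cn1c(-c2ccc(Cl)cc2)c(C2CCCCC2)c2ccc(C(=O)NC(C)(C)C(=O)Nc3ccc(/C=C/C(=O)O)cc3)cc21` gives 0.6 ug/mL in this assay. Compound 3 `Cn1c(-c2ccc3ncccc3c2)c(C2CCCCC2)c2ccc(C(=O)NC(C)(C)C(=O)Nc3ccc(/C=C/C(=O)O)cc3)cc21` gives 0.3 ug/mL in this assay, the lower of the two numbers, separated from compound 2 by a 2.0-fold lower number from compound 2 to compound 3 (0.30 log units; within the scatter). Replacing thiophen-2-yl produced an at least 6.0-fold higher number from compound 1 to compound 2 (0.77 log units; beyond the scatter) and an at least 3.0-fold higher number from compound 1 to compound 3 (0.47 log units; beyond the scatter), both counted from the limit (the limit of < 0.1 ug/mL in this assay, at which 1 of the 3 values shown sits). Compound 4 `Cn1c(-c2ccc(N)cn2)c(C2CCCCC2)c2ccc(C(=O)NC(C)(C)C(=O)Nc3ccc(/C=C/C(=O)O)cc3)cc21` carries 5-aminopyridin-2-yl in place of quinolin-6-yl on an aromatic carbon. Only these aryl exchanges bear on the step, and they point to small or modest shifts. A modest rise in this assay is expected for compound 4, a 5.0-fold higher number from compound 3 to compound 4 (0.70 log units; beyond the scatter). Compound 4 is estimated at 1.5 ug/mL, within 0.3 ug/mL to 6 ug/mL.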

Compound 4, solubility: 238 ug/mL
Estimate against measurement, compound 4: 160-fold (2.20 log units) below; the measured number lies above the stated range.
By their numbers in this assay, from the lowest: compounds 3 and 2 (each within the scatter of the next); then compound 4. At a limit, below all of these: compound 1.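

At this aryl position on the shared core, this assay can move far more than the earlier exchanges showed: 5-aminopyridin-2-yl in place of quinolin-6-yl gives a 790-fold higher number from compound 3 to compound 4 (2.90 log units; beyond the scatter), and in place of 4-chlorophenyl it gives a 400-fold higher number from compound 2 to compound 4 (2.60 log units; beyond the scatter). Against thiophen-2-yl the step reads an at least 2300-fold higher number from compound 1 to compound 4 (3.37 log units; beyond the scatter), and it starts from a limit, not a number: the limit of < 0.1 ug/mL in this assay, at which 1 of the 4 values shown sits.

Against quinolin-6-yl, the change swaps the ring count and adds a hydrogen-bond donor, and these compounds cannot separate those differences. Going by these compounds, how a plain pyridin-2-yl or an aminophenyl would read in this assay stays open, and with it whether the amine or the ring nitrogen carries the step.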